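Lengthening the chain toward a long phenoxy ester

The source may report more compounds than this note shows. Statements on the series, on what has been measured and on what is new or still open speak of the compounds shown alone.

Compound 2 `O=C(CCCCCc1ccccc1)OCC1COCCOCCOCCOCCOCCO1` gives 79000 nM in a functional assay on HeLa cells (Homo sapiens) for inhibition, read by sulforhodamine B assay, with a stated time of 48 h (a lower number here means a stronger inhibitor of growth, a higher number a weaker inhibitor of growth), the highest of the two numbers shown; its nearest neighbour is compound 3 `O=C(/C=C/c1ccccc1)OCC1COCCOCCOCCOCCOCCO1`, which gives 48000 nM, and the step of a 1.6-fold lower number from compound 2 to compound 3 (0.22 log units; within the scatter) stays within the scatter. Compound 1 `O=C(CCCCOc1ccccc1)OCC1COCCOCCOCCOCCOCCO1` returns only a limit in this assay, > 100000 nM. Compound 4 `O=C(CCCCCCCCCCOc1ccccc1)OCC1COCCOCCOCCOCCOCCO1` differs from compound 2 by 5-phenoxypentyl in place of phenyl on a saturated chain carbon, five bonds along the chain from a carbonyl carbon. The measured step of an at least 1.2-fold lower number from compound 1 to compound 2 (0.10 log units; that floor lies within the scatter) exchanged phenoxy for benzyl and barely moved the number, so the present change, which lengthens the chain and brings a phenoxy back, is expected to shift little. The step of a 1.2-fold lower number from compound 2 to compound 4 (0.08 log units; within the scatter) is therefore expected to lie within the scatter. Compound 4 is estimated at 65000 nM, with a range from 20000 nM to 200000 nM.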

Compound 4, concentration for 50% growth inhibition: 41000 nM
Estimate against measurement, compound 4: 1.6-fold (0.20 log units) above; the range from low to high includes it.
By their numbers in this assay, from the lowest: compounds 4, 3 and 2 (each within the scatter of the next). At a limit, above all of these: compound 1.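

Swapping phenyl for 5-phenoxypentyl on a saturated chain carbon, five bonds along the chain from a carbonyl carbon, gives a 1.9-fold lower number from compound 2 to compound 4 (0.28 log units; within the scatter) in this assay. This position therefore accepts a group of 12 heavy atoms with 1 hydrogen-bond acceptor in place of one of 6 heavy atoms with none, without a change beyond the scatter. Going by these compounds, whether an amine or a carboxylic acid at the chain end, or a longer chain, would move the number beyond the scatter stays open. How far compound 1 lies from compound 4 also stays open, as compound 1 gives only a limit: the limit of > 100000 nM in this assay, at which 1 of the 4 values shown sits.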